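A few compounds are considered here, and "the series" means these few. Any claim that something is new, unique, unknown or untested is made for them only; others in the source may bear on it.

The measured compounds and their values:

compound 1, `COc1ccc(C2SCC(=O)N2CCN2CCCCC2)cc1`: 100%
compound 2, `O=C1CSC(c2ccc([N+](=O)[O-])cc2)N1CCN1CCCCC1`: 100%
compound 3, `COc1ccccc1C1SCC(=O)N1CCN1CCCCC1`: 100%

All three were run in an ADME assay on Vero cells (Chlorocebus sabaeus) for cytotoxicity, read by neutral red uptake, tested at 49 ug/mL; on this read-out higher numbers stand for a weaker effect at the one concentration tested and lower numbers for a stronger effect. Compound 1 and compound 2 differ in one place, (nitro in place of methoxy on an aromatic carbon), and the step of no change at the digits printed from compound 1 to compound 2 (within the scatter) lies within the scatter of repeated measurements. Compound 3 has the same atoms as compound 1, joined differently; the difference between the two cores is not broken down here. Its value in this assay is level with those of compound 1 and compound 2 at the digits reported, so nothing among the three measured compounds separates them on this read-out.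

Compound 4, `O=C1CSC(c2ccccc2[N+](=O)[O-])N1CCN1CCCCC1`, has not yet been measured. It is related to compound 3 by nitro in place of methoxy on an aromatic carbon, the same kind of change as that from compound 1 to compound 2, though not the same: in compound 2 the entering group sits para to a large group, while in compound 4 it sits ortho to a large group. Since the step from compound 1 to compound 2 in this assay was no change at the digits printed from compound 1 to compound 2 (within the scatter) and compound 3 already stands level with compound 1, the step from compound 3 to compound 4 is expected to be about no change at the digits printed from compound 3 to compound 4 (within the scatter), again within the scatter. Compound 4 is therefore estimated at 100% in this assay, with a range from 88% to 105%.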

Compound 4, a percentage reported as activity, at one concentration (the size of the read-out at that concentration, not a potency): 100%
Compound 4: middle estimate and measured number agree at the digits printed; measured number inside the range.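

In this assay, nitro in place of methoxy on an aromatic carbon, here ortho to a large group, gives no change at the digits printed from compound 3 to compound 4 (within the scatter). Set beside the earlier step on the core of compound 1, the change behaves alike on both cores, whichever of the two places on the aromatic ring it occupies: the same change on two cores in this assay, no change at the digits printed (within the scatter) from compound 1 to compound 2 and no change at the digits printed (within the scatter) from compound 3 to compound 4, 0 percentage points apart, within the scatter of two such steps This does not show that the change is without consequence in general, since all four compounds read level in this one assay at its single concentration, so the agreement is between two steps that show no movement, and neither step shows how the change would carry over on a core where the read-out departs from this level; it also gives no potency and says nothing about any other concentration or cell type.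

The compounds shown leave open whether other groups on the aromatic ring, such as a carboxylic acid, an amine or a chlorine atom, would also stand level with these four. They also leave open whether a longer chain joining the two parts of the molecule would keep the read-out where it stands.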